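Adding a hydroxy group to a weak growth inhibitor

The source may hold more compounds than are shown below. What is called first, only, known or untested is meant among the compounds shown, and "the series" means these compounds.

Compound 1 `COc1ccc(-n2cnnc2-c2cc(OC)c(OC)c(OC)c2)cc1` gives 4370 nM
Compound 2 `COc1cc(-c2nncn2-c2ccc(N(C)C)cc2)cc(OC)c1OC` gives 151 nM

Both values come from a functional assay on U-251 cells (Homo sapiens) for inhibition (on this read-out higher numbers stand for weaker inhibition of growth and lower numbers for stronger inhibition of growth), and compound 1 holds the higher number of the pair, so it is the weaker growth inhibitor of the two. For the measured compounds named here, the only measured step is a 29-fold lower number from compound 1 to compound 2 (1.46 log units; beyond the scatter) and it is large and beyond the scatter. In that step dimethylamino takes the place of methoxy on an aromatic carbon.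

The next compound is compound 3 `COc1ccc(-n2cnnc2-c2cc(OC)c(OC)c(OC)c2)cc1O` and its structural change from compound 1 is hydroxy in place of hydrogen on an aromatic carbon with the hydroxy ortho to a methoxy group and meta to a large group. Going by the values given here, no measured step adds a hydroxy group, so the evidence is indirect. The step to compound 2 a 29-fold lower number from compound 1 to compound 2 (1.46 log units; beyond the scatter) shows only that this assay can respond strongly to a change at that methoxy group. A sizeable move toward a lower number is therefore expected, though probably with wide uncertainty. The expected step is a 17-fold lower number from compound 1 to compound 3 (1.24 log units; beyond the scatter) in this estimate. For compound 3 the estimated value is 250 nM with an expected range from 30 nM to 2000 nM in this assay.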

Compound 3, concentration for 50% growth inhibition: 407 nM
Compound 3: the middle estimate sits 1.6-fold (0.21 log units) below what was measured, within the range that was stated.
By their numbers in this assay, from the lowest: compound 2; then compound 3; then compound 1.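

In this assay the new result gives an 11-fold lower number from compound 1 to compound 3 (1.03 log units; beyond the scatter) and shows that the position ortho to a methoxy group and meta to a large group is itself sensitive, since hydroxy in place of hydrogen produces a large change while the methoxy group stays in place. For the compounds shown here, the earlier pair showed only that replacing that methoxy group could matter, through a 29-fold lower number from compound 1 to compound 2 (1.46 log units; beyond the scatter) and its exchange of methoxy for dimethylamino. The hydroxy result adds that the same ring can respond strongly to an added group, with no existing substituent removed, but no supporting measurement accounts for this response.

The compounds shown do not tell whether the step is particular to hydroxy or whether an amine, a fluorine atom or a second methoxy group at this position would give a similar change. They also leave open whether hydroxy and dimethylamino together on this ring would add to each other, and whether the shift seen in growth inhibition would hold in cells other than U-251.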